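The source may hold more compounds than are shown below. What is called first, only, known or untested is meant among the compounds shown, and "the series" means these compounds.

Compound 1 `Cc1ccccc1Nc1nc(Nc2ccccc2)ncc1Cl`: > 100000 nM, a limit of a functional assay on MCF7 cells (Homo sapiens) for inhibition, read by CCK-8 assay, with a stated time of 48 h; a higher number here means a weaker inhibitor of growth, a lower number a stronger inhibitor of growth.
Compound 2 `Cc1ccc(Nc2ncc(Cl)c(Nc3ccccc3C)n2)cc1`: > 100000 nM, a limit of this assay.

Compound 2 has no number in this assay, only a limit. The evidence so far is the limit of > 100000 nM in this assay, at which 2 of the 2 values shown sit. Compound 3 `Cc1ccccc1Nc1nc(Nc2ccc(N3CCN(C)CC3)cc2)ncc1Cl` carries 4-methylpiperazin-1-yl in place of methyl on an aromatic carbon of a six-membered aromatic ring of carbon only, para to a large group: 4-methylpiperazin-1-yl in place of methyl on an aromatic carbon.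

Within the data shown here, the only measured step is a step that the two limits leave unreadable from compound 1 to compound 2. It offers no size to carry over, and it concerns a far smaller change than this one. The expectation therefore rests on the size of the structural change alone, and it is weak: some growth inhibition may become measurable, though another limit remains possible. The estimated step is an at least 5.0-fold lower number from compound 2 to compound 3 (0.69 log units; beyond the scatter), towards stronger inhibition. For compound 3 the expected value is 20000 nM, with an estimated range of 3000 nM to 100000 nM.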

Compound 3, concentration for 50% growth inhibition: 20600 nM
Compound 3: middle estimate off by 1.0-fold (0.01 log units), on the low side, and the stated range covers the measured number.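

In this assay, among these compounds, 4-methylpiperazin-1-yl in place of methyl, on an aromatic carbon para to a large group, yields the only number of the three compounds, with an at least 4.8-fold lower number from compound 2 to compound 3 (0.68 log units; beyond the scatter). With hydrogen as the reference at the same place, the change gives an at least 4.8-fold lower number from compound 1 to compound 3 (0.68 log units; beyond the scatter), while the step from hydrogen to methyl cannot be read. Both readable steps give only a lower bound on size, because one end of each is a limit: the limit of > 100000 nM in this assay, at which 2 of the 3 values shown sit.

Open, from the compounds shown here alone, is whether the effect follows from the ring of 4-methylpiperazin-1-yl or from its nitrogens; a morpholin-4-yl, a piperidin-1-yl or an open dimethylamino group at this place would separate these. Also open, going by these compounds, is how much of the effect depends on the rest of the shared core, which is the same in all three compounds.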